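Notes on replacing cyano with methoxycarbonyl

The compounds below may be only part of what the source reports. "The series", "measured", "known", "first", "only" and "open" are said of these compounds alone.

- compound 1 `CN(C)C(=O)c1cc2cnc(Nc3ccc(NC(=O)C4(C(=O)Nc5ccccc5F)CC4)cc3)nc2n1C1CCCC1`: 88.6%
- compound 2 `CN(C)C(=O)c1cc2cnc(Nc3ccc(NC(=O)C4(C(=O)Nc5cccc(C#N)c5)CC4)cc3)nc2n1C1CCCC1`: 73.6%

Both values come from a functional assay on A549 cells (Homo sapiens) for inhibition, read by CCK-8 assay, with a stated time of 72 h, tested at 10 uM; a lower number here means less inhibition of growth, a higher number more inhibition of growth at the concentration tested. Compound 2 stands lowest of the two at 73.6%, and compound 1 lies above it by more than the scatter. The next compound is compound 3 `COC(=O)c1cccc(NC(=O)C2(C(=O)Nc3ccc(Nc4ncc5cc(C(=O)N(C)C)n(C6CCCC6)c5n4)cc3)CC2)c1`, and the change is methoxycarbonyl in place of cyano on an aromatic carbon. This places methoxycarbonyl in place of cyano on an aromatic carbon, meta to a large group.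

Within the data shown here, only one measured step bears on this: a number 15 percentage points lower from compound 1 to compound 2 (beyond the scatter). That modest step swaps 2-fluorophenyl for 3-cyanophenyl on an amide-type nitrogen, so it touches the same substituent of the molecule but does not test methoxycarbonyl. Among the measured compounds shown here, it gives no direction for the new group, and no measured pair does. A shift in this assay no larger than that step is expected, in either direction, and most likely none beyond the scatter. The estimated step is a number 1.6 percentage points lower from compound 2 to compound 3 (within the scatter). The estimate for compound 3 is 72%, with an expected range of 56% to 88%.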

Compound 3, percent growth inhibition at one concentration: 91%
Estimate against measurement, compound 3: 19 percentage points below, and the stated range ends below it.
By their numbers in this assay, from the lowest: compound 2; then compounds 1 and 3 (each within the scatter of the next).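

In this assay, methoxycarbonyl on this aromatic carbon, meta to a large group, gives a number 17.4 percentage points higher from compound 2 to compound 3 (beyond the scatter), so the lower number seen with cyano does not extend to every substituent at this place. Measured against the 2-fluorophenyl amide, the new aryl group gives a number 2.4 percentage points higher from compound 1 to compound 3 (within the scatter), so 3-(methoxycarbonyl)phenyl and 2-fluorophenyl on the amide-type nitrogen cannot be told apart in this read-out. No measurement at hand accounts for the difference between cyano and methoxycarbonyl.

The compounds shown do not settle whether the higher number belongs to methoxycarbonyl in particular or would also come with other groups on the same aromatic carbon, such as a carboxylic acid, a primary amide or a methoxy group. From the compounds shown here alone, with one test concentration, it also remains open whether compound 1 and compound 3 would separate across a range of concentrations in this assay.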